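A pyridin-3-yl group replaces 3-(trifluoromethyl)phenyl

The compounds below may be only part of what the source reports. "The series", "measured", "known", "first", "only" and "open" are said of these compounds alone.

In a functional assay on HEK293 cells (Homo sapiens) for cytotoxicity (on this read-out lower numbers stand for higher toxicity in this test and higher numbers for lower toxicity in this test), compound 3 (`COc1ccc([C@H]2CC(=O)N(c3cccc(C(F)(F)F)c3)C2)cc1OC1CCCC1`) gives > 10000 nM as a limit of the assay and not a number. Compound 1 (`COc1ccc([C@H]2CC(=O)N(c3cc(N)cc(F)c3)C2)cc1OC1CCCC1`) gives > 10000 nM as a limit too. Compound 2 (`COc1ccc([C@H]2CC(=O)N(c3ccccc3C(F)(F)F)C2)cc1OC1CCCC1`) gives > 10000 nM as a limit too. Compound 3 thus shares the limit of > 10000 nM in this assay, at which 3 of the 3 values shown sit, and has no exact position of its own. The change to compound 4 (`COc1ccc([C@H]2CC(=O)N(c3cccnc3)C2)cc1OC1CCCC1`) is pyridin-3-yl in place of 3-(trifluoromethyl)phenyl on an amide-type nitrogen in a ring on the amide-type nitrogen in a ring of the shared core. The closest evidence comes from swaps at that same place. These are a step that the two limits leave unreadable from compound 1 to compound 2 and a step that the two limits leave unreadable from compound 1 to compound 3 and a step that the two limits leave unreadable from compound 2 to compound 3 and none of them gives a size. None of the three groups tried there brought a number within reach of this assay so no direction can be read. The estimated outcome is a step that the limit leaves unreadable from compound 3 to compound 4 and no clear shift in either direction is expected. For compound 4 the estimate is 15000 nM with an expected range from 6000 nM to 40000 nM and the most likely report is again only a limit.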

Compound 4, half-maximal cytotoxic concentration: > 10000 nM
Compound 4 was reported as a limit (the forecaster's own chance of this, stated with the estimate: 85%); the middle value does not contradict the limit.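

In this assay compound 4 gives > 10000 nM, which is a limit of the assay and not a number. The steps to compound 4 from compound 1, compound 2 and compound 3 cannot be read, since all four share one limit: the limit of > 10000 nM in this assay, at which 4 of the 4 values shown sit.

The compounds shown leave open at what concentration any of them harms these cells, and whether the group on the amide-type nitrogen in a ring changes that concentration.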